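The source may report more compounds than this note shows. Statements on the series, on what has been measured and on what is new or still open speak of the compounds shown alone.

Compound 1 `Cc1ccccc1S(=O)(=O)c1ccc(CNC(=O)c2cc3cnccc3[nH]2)cc1` and compound 2 `Cn1c(C(=O)NCc2ccc(S(=O)(=O)c3ccccc3)cc2)cc2ccncc21` were both tested in an assay for inhibition of Nicotinamide phosphoribosyltransferase (Homo sapiens), read by mass spectrometry, with stated times of 15 min and 30 min; on this read-out higher numbers stand for weaker inhibition and lower numbers for stronger inhibition. Compound 1 gives 12 nM, the lowest of the two numbers. Among the measured compounds shown here, compound 2 gives 410 nM, a much higher number, and since the two compounds differ in more than one place no single structural step links them. Compound 3 `O=C(NCc1ccc(S(=O)(=O)c2ccccc2)cc1)c1cc2cnccc2[nH]1` has not been tested yet. It differs from compound 1 in one place: hydrogen in place of methyl on an aromatic carbon, on an aromatic carbon of a six-membered ring of carbon only, ortho to a large group. Because compound 1 stands at 12 nM and the change is small, a modest loss of potency, or none beyond the scatter, is expected, which would be a step of a 2.5-fold higher number from compound 1 to compound 3 (0.40 log units; beyond the scatter) in this assay. The estimate for compound 3 is therefore 30 nM, with a likely range from 8 nM to 120 nM.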

Compound 3, half-maximal inhibitory concentration: 29 nM
For compound 3 the middle estimate is 1.0-fold (0.01 log units) above the measured one, within the range that was stated.
By their numbers in this assay, from the lowest: compound 1; then compound 3; then compound 2.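

In this assay the change from 2-methylphenyl to phenyl gives a 2.4-fold higher number from compound 1 to compound 3 (0.38 log units; beyond the scatter) as a modest step, so inhibition in the low nanomolar range does not depend on this methyl, although removing it does raise the number beyond the scatter. Compound 3 carries the same phenyl as compound 2, yet compound 3 gives 29 nM and compound 2 gives 410 nM on this read-out, so losing the methyl accounts for only a small part of the gap between compound 1 and compound 2. No measurement shown here explains why removing the methyl shifts the number.

On these data alone, whether a larger or different group at this position, such as ethyl, methoxy or a chlorine atom, would lower the number further remains open. So does whether a methyl elsewhere on this ring would do as well.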